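Weighing a bromine-for-fluorine swap on a pancreatic-cancer cell assay

A few compounds are considered here, and "the series" means these few. Any claim that something is new, unique, unknown or untested is made for them only; others in the source may bear on it.

Compound 1 `COc1cc(NC(C)CCCNC(=O)NNC(=O)Nc2cccc(F)c2)c2ncccc2c1` is the weakest of the three measured compounds: in a functional assay on MIA PaCa-2 cells (Homo sapiens) for inhibition, read by MTT assay, with a stated time of 72 h (on this read-out lower numbers stand for stronger inhibition and higher numbers for weaker inhibition), compound 1 gives 69000 nM, the highest number of the set. Compound 3 `COc1cc(NC(C)CCCNC(=O)Nc2ccc(F)cc2)c2ncccc2c1` gives 21000 nM and is nearest, while compound 2 `COc1cc(NC(C)CCCNC(=O)NNC(=O)Nc2cc(C(F)(F)F)cc(C(F)(F)F)c2)c2ncccc2c1` gives 20000 nM and lies furthest. Within the data shown here, the one single-point step among them, a 3.3-fold lower number from compound 1 to compound 3 (0.52 log units; beyond the scatter), shortens the linker rather than changing the aryl substitution.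

Compound 4 `COc1cc(NC(C)CCCNC(=O)NNC(=O)Nc2ccc(Br)cc2)c2ncccc2c1` keeps the whole framework of compound 1 and differs only at the far end: 4-bromophenyl in place of 3-fluorophenyl on an amide-type nitrogen. Among the measured compounds shown here, no measured step changes the substitution of the terminal ring alone, so the expectation rests on indirect hints. Compound 2 carries the same linker as compound 1 with a differently substituted terminal ring and its number is lower, which suggests that this position tolerates change and that a different substituent can bring a modest gain. Given that, a small improvement for compound 4 in this assay is expected, though it may well stay within the scatter: the step is estimated as a 2.0-fold lower number from compound 1 to compound 4 (0.29 log units; within the scatter). The estimated value for compound 4 is 35000 nM, with a range from 12000 nM to 90000 nM.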

Compound 4, half-maximal inhibitory concentration: 231000 nM
Compound 4: the middle estimate sits 6.6-fold (0.82 log units) below what was measured; measured number above the stated range.
By their numbers in this assay, from the lowest: compounds 2 and 3 (each within the scatter of the next); then compound 1; then compound 4.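

The terminal ring on this amide-type nitrogen turns out to be sensitive in this assay: replacing 3-fluorophenyl with 4-bromophenyl gives a 3.3-fold higher number from compound 1 to compound 4 (0.52 log units; beyond the scatter), so a change at this ring can weaken the compound, even though the two groups have the same count of heavy atoms and the same counts of hydrogen-bond donors and acceptors. The wider comparison gives an 11-fold higher number from compound 3 to compound 4 (1.04 log units; beyond the scatter), a large step that is harder to interpret, since ((4-bromophenyl)carbamoyl)amino replaces 4-fluorophenyl and the difference therefore covers both the extra carbamoyl-amino stretch of the linker and the change of halogen. Nothing available here explains why the number rises in either step.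

The swap from compound 1 to compound 4 changes both the halogen and the place it occupies on the ring, so these two effects cannot yet be told apart. A 3-bromophenyl or a 4-fluorophenyl on this same linker would separate them, and a 4-chlorophenyl would show whether the number climbs steadily on going from fluorine to bromine at that place.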